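Working notes: phenyl to ethyl, compound 3 to compound 4

This account rests on a few compounds, and the source may have more. Where it says the series, first, only, none or still open, it means among the compounds named here.

Measured so far in an assay on CHO cells for displacement of a labelled ligand from prostaglandin E2 receptor EP4 subtype (Mus musculus), read by scintillation counting, with a stated time of 60 min; a higher number here means a weaker inhibitor, a lower number a stronger inhibitor:
compound 1 `O=C(O)CCCSCCN1C(=O)OC[C@@H]1/C=C/[C@@H](O)Cc1ccccc1`: 4.2 nM
compound 2 `O=C(O)CCCSCCN1C(=O)OC[C@@H]1/C=C/[C@@H](O)Cc1cccc(C(F)(F)F)c1`: 2 nM
compound 3 `O=C(O)CCCSCCN1C(=O)OC[C@@H]1/C=C/[C@@H](O)Cc1cccc(-c2ccccc2)c1`: 28 nM

Compound 3 has the highest number of the three in this assay; its nearest neighbour is compound 1, and compound 2 lies furthest away. The steps of a 6.7-fold higher number from compound 1 to compound 3 (0.82 log units; beyond the scatter) and a 14-fold higher number from compound 2 to compound 3 (1.15 log units; beyond the scatter) both show the phenyl group carrying a clearly higher number. Compound 4 `CCc1cccc(C[C@H](O)/C=C/[C@H]2COC(=O)N2CCSCCCC(=O)O)c1` differs from compound 3 by ethyl in place of phenyl on an aromatic carbon. Among the compounds with values here, no measured step swaps phenyl for ethyl directly; the two steps that introduce phenyl are the only bearing on it. With phenyl removed and a small chain in its place, the number for compound 4 is expected to fall back toward that of compound 1, a step of a 5.6-fold lower number from compound 3 to compound 4 (0.75 log units; beyond the scatter). Compound 4 is estimated at 5 nM, range 2 nM to 15 nM.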

Compound 4, inhibition constant: 7.9 nM
Beside the measured number, compound 4's estimate is 1.6-fold (0.20 log units) below it; measured number inside the range.
By their numbers in this assay, from the lowest: compound 2; then compounds 1 and 4 (each within the scatter of the next); then compound 3.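

In this assay the step of a 3.5-fold lower number from compound 3 to compound 4 (0.55 log units; beyond the scatter) ties the higher number of compound 3 to phenyl rather than to substitution at this place as such. The step of a 1.9-fold higher number from compound 1 to compound 4 (0.27 log units; within the scatter) leaves ethyl level with hydrogen, while a 4.0-fold higher number from compound 2 to compound 4 (0.60 log units; beyond the scatter) sets ethyl apart from trifluoromethyl, so these two non-ring groups do not read alike. No evidence on the cause of these steps is at hand.

From the compounds shown here alone, whether a longer chain such as propyl stays level with ethyl or moves toward phenyl remains open. So does how a methoxy group or a chlorine atom would read at this place on the ring.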